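The compounds below may be only part of what the source reports. "The series", "measured", "known", "first", "only" and "open" are said of these compounds alone.

Measured compounds in the series:
- compound 1 `O=C(Nc1ccc(Oc2ccnc3[nH]ccc23)cc1)c1cc2cccnc2n(-c2ccccc2)c1=O`: 1580 nM
- compound 2 `O=C(Nc1ccc(Oc2ccnc3[nH]ccc23)c(F)c1)c1cc2cccnc2n(-c2ccc(Cl)cc2)c1=O`: "not determined" (no result reported)
- compound 3 `Cn1ccc2c(Oc3ccc(NC(=O)c4cc5cccnc5n(-c5ccccc5)c4=O)cc3)ccnc21`: 5030 nM

In a functional assay on U-87MG ATCC cells for antiproliferative activity against U-87 MG (Homo sapiens), read by MTT assay, with a stated time of 72 h (a lower number here means a stronger inhibitor, a higher number a weaker inhibitor), compound 1 gives 1580 nM, while compound 3, which carries a methyl in place of hydrogen on an aromatic nitrogen, gives 5030 nM. For the measured compounds named here, that single change is the only measured step: a 3.2-fold higher number from compound 1 to compound 3 (0.50 log units; beyond the scatter). Compound 3 therefore stands at the higher of the two numbers recorded, with compound 1 as its nearest neighbour. Compound 2 carries a chlorine on the phenyl attached to the core nitrogen and a fluorine on the central ring, but for compound 2 the result is "not determined" (no result reported), so nothing can be drawn from it.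

Compound 4 `Cn1ccc2c(Oc3ccc(NC(=O)c4cc5cccnc5n(-c5ccc(C(F)(F)F)cc5Cl)c4=O)cc3)ccnc21` differs from compound 3 in one place: 2-chloro-4-(trifluoromethyl)phenyl in place of phenyl on an aromatic nitrogen. Going by the values given here, no measured pair bears on this exchange; the only step recorded concerns the methyl on the aromatic nitrogen, at the other end of the molecule, and compound 2, the only other analogue with a substituted phenyl at this position, has no result. The expectation for this assay must therefore rest on compound 3 alone, with wide uncertainty and no firm direction.

On that basis compound 4 is estimated at 3500 nM, within a range of 1200 nM to 10000 nM, which corresponds to an expected step of a 1.4-fold lower number from compound 3 to compound 4 (0.16 log units; within the scatter).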

Compound 4, half-maximal inhibitory concentration: 12600 nM
Compound 4: the middle estimate sits 3.6-fold (0.56 log units) below what was measured, outside the stated range (above it).
By their numbers in this assay, from the lowest: compound 1; then compound 3; then compound 4.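

In this assay, replacing phenyl with 2-chloro-4-(trifluoromethyl)phenyl on the aromatic nitrogen gives a 2.5-fold higher number from compound 3 to compound 4 (0.40 log units; beyond the scatter), the only readable step at this position in the compounds shown. The number at this position therefore responds to the substitution on the phenyl, and this particular substituted phenyl gives a weaker inhibitor than the unsubstituted one, at least with the methyl on the other aromatic nitrogen. Both readable single changes now point the same way, since the methyl step is a 3.2-fold higher number from compound 1 to compound 3 (0.50 log units; beyond the scatter), although they sit at opposite ends of the molecule and neither says anything about the other. No measurement at hand explains the rise at this position.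

The chlorine and the trifluoromethyl enter together, so the share of each remains unresolved, as does whether the same exchange would act alike on compound 1, which keeps the hydrogen on that aromatic nitrogen. Also open, from the compounds shown here alone, is how the position would respond to a phenyl carrying only a fluorine, a methoxy group, an amine or a carboxylic acid, or to a saturated ring such as cyclohexyl in place of the phenyl.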